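Swapping the basic ring on a sulfonylindole

A few compounds are considered here, and "the series" means these few. Any claim that something is new, unique, unknown or untested is made for them only; others in the source may bear on it.

Measured compounds:
compound 1, `O=S(=O)(c1cccc2ccccc12)n1ccc2ccc(N3CCN4CCCCC4C3)cc21`, 1.7 nM
compound 2, `O=S(=O)(c1ccc2ccccc2c1)n1ccc2ccc(N3CCN4CCCCC4C3)cc21`, 3 nM

Both were tested in an assay on HEK293 cells for displacement of a labelled ligand from 5-hydroxytryptamine receptor 6 (Homo sapiens); on this read-out higher numbers stand for weaker inhibition and lower numbers for stronger inhibition. Compound 1 gives 1.7 nM, the lower of the two numbers. Its nearest neighbour is compound 2; the change from compound 1 to compound 2 was a 1.8-fold higher number from compound 1 to compound 2 (0.25 log units; within the scatter), so the two cannot be ranked.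

Compound 3, `O=S(=O)(c1cccc2ccccc12)n1ccc2ccc(C3=CCN4CCCC4C3)cc21`, has not yet been measured. It differs from compound 1 in the basic part: a group of 9 heavy atoms (8 carbon, 1 nitrogen; one five-membered non-aromatic ring with 1 hetero atom, one six-membered non-aromatic ring with 1 hetero atom) in place of a group of 10 heavy atoms (8 carbon, 2 nitrogen; one six-membered non-aromatic ring with 1 hetero atom, one six-membered non-aromatic ring with 2 hetero atoms), on an aromatic carbon. Among the compounds with values here, the only measured step, naphthalen-2-yl in place of naphthalen-1-yl on the sulfonyl sulfur, touches a different part of the molecule and says nothing direct about the basic ring, so no measured step bears on this change. The replacement is larger than the measured one, and one of the two nitrogens is lost, which leaves the outcome uncertain. The step from compound 1 to compound 3 in this assay is therefore expected to be a 2.9-fold higher number from compound 1 to compound 3 (0.47 log units; beyond the scatter), a modest weakening at most. Compound 3 is estimated at 5 nM, within 1.5 nM to 20 nM.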

Compound 3, inhibition constant: 1.3 nM
Beside the measured number, compound 3's estimate is 3.8-fold (0.59 log units) above it, outside the stated range (below it).
By their numbers in this assay, from the lowest: compounds 3, 1 and 2 (each within the scatter of the next, the first and the last beyond it).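

In this assay, the new group on the aromatic carbon gives a 1.3-fold lower number from compound 1 to compound 3 (0.12 log units; within the scatter), so compound 1 and compound 3 cannot be ranked. The earlier compounds shown here differed only in the naphthalene attachment on the sulfonyl sulfur, whereas this pair shows that the other end of the molecule can accept a substantial change without leaving the low range of numbers. Compound 3 has one nitrogen fewer, one hydrogen-bond acceptor fewer, a five-membered ring in place of a six-membered one and a double bond outside aromatic rings, yet it cannot be distinguished from compound 1, and no supporting data explain this similarity.

On these data alone, these differences arrive together, so the contribution of each remains unknown, including whether the double bond matters or the second nitrogen can be lost on its own. As far as these compounds go, it also remains open how far this tolerance extends, for example to a simple piperidine or piperazine ring or to an open-chain dimethylaminoethyl group at the same carbon, or whether the new group behaves the same way with naphthalen-2-yl on the sulfonyl sulfur.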